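The source may hold more compounds than are shown below. What is called first, only, known or untested is meant among the compounds shown, and "the series" means these compounds.

Measured so far in a functional assay on RS4-11 cells (Homo sapiens) for inhibition, read by CCK-8 assay, with a stated time of 48 h; a lower number here means a stronger inhibitor, a higher number a weaker inhibitor:
Compound 1 `O=[N+]([O-])c1ccc(NC(=S)N2CCN(S(=O)(=O)c3sccc3-c3ccccc3Oc3ccc(O)c(O)c3)CC2)cc1` gives 9000 nM.
Compound 2 `O=C(NCCNS(=O)(=O)c1ccc(-c2ccccc2OCc2cccc(O)c2)s1)Nc1cc(Cl)cc(Cl)c1` gives only a limit of the assay, > 50000 nM.

Among the measured compounds shown here, compound 1 stands as the only actual number in this assay; the other value is a limit (the limit of > 50000 nM in this assay, at which 1 of the 2 values shown sits). Compound 3 `O=C(Nc1ccc(F)cc1)N1CCN(S(=O)(=O)c2sccc2-c2ccccc2Oc2ccc(O)c(O)c2)CC1` has not yet been measured. It differs from compound 1 on an amine nitrogen in a ring of a six-membered non-aromatic ring with 2 nitrogen, where a (4-fluorophenyl)carbamoyl enters: a group of 10 heavy atoms (7 carbon, 1 nitrogen, 1 oxygen, 1 fluorine; one six-membered aromatic ring of carbon only) in place of a group of 12 heavy atoms (7 carbon, 2 nitrogen, 2 oxygen, 1 sulfur; one six-membered aromatic ring of carbon only), on an amine nitrogen in a ring. For the measured compounds named here, no step between measured compounds is available, so nothing measured shows how this assay responds to a change at that nitrogen. Compound 1 is already a weak inhibitor here. The step is expected to be a 1.7-fold higher number from compound 1 to compound 3 (0.22 log units; within the scatter), small, within the scatter or toward weaker inhibition. Compound 3 is estimated at 15000 nM, with a range from 4000 nM to 50000 nM.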

Compound 3, half-maximal inhibitory concentration: 6800 nM
The estimate for compound 3 lay 2.2-fold (0.34 log units) above the measured number, within the range that was stated.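

In this assay, (4-fluorophenyl)carbamoyl on the amine nitrogen of the six-membered non-aromatic ring, in place of the group in compound 1, gives a 1.3-fold lower number from compound 1 to compound 3 (0.12 log units; within the scatter), the first step read at this position. This exchange therefore leaves the number unchanged within the scatter, and compound 3, at 6800 nM, remains a weak inhibitor, as compound 1 was. Nothing available gives a cause for this step or bears on it.

On these data alone, both groups carry one six-membered aromatic ring of carbon only, so the effect of removing that ring, for example with a plain acetyl group, remains open. Also open, as far as these compounds go, is whether an amine, a carboxylic acid or a longer chain on this nitrogen would move the number beyond the scatter.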